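The compounds below may be only part of what the source reports. "The series", "measured", "known", "first", "only" and "open" are said of these compounds alone.

Measured compounds, in a functional assay on HEK293 cells for activation of melanin-concentrating hormone receptor 1 (Rattus norvegicus), read by inositol phosphate accumulation; a higher number here means that more compound is needed for the effect, a lower number that less compound is needed:
- Compound 1 `O=C(CCc1ccc(C(F)(F)F)cc1)Nc1ccc2nc(N3CCC(NS(=O)(=O)O)C3)ccc2c1`: 50 nM
- Compound 2 `CC1CCCN1c1ccc2cc(NC(=O)CCc3ccc(C(F)(F)F)cc3)ccc2n1`: 270 nM
- Compound 3 `O=C(CCc1ccc(C(F)(F)F)cc1)Nc1ccc2nc(N3CCC(c4ccccc4)C3)ccc2c1`: 1770 nM

Compound 3 stands highest of these three numbers in this assay; its nearest neighbour is compound 2, at a 6.6-fold higher number from compound 2 to compound 3 (0.82 log units; beyond the scatter), and its furthest is compound 1, at a 35-fold higher number from compound 1 to compound 3 (1.55 log units; beyond the scatter).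

Compound 4 `NC1CCN(c2ccc3cc(NC(=O)CCc4ccc(C(F)(F)F)cc4)ccc3n2)C1` differs from compound 3 by amino in place of phenyl on a saturated ring carbon. Within the data shown here, the step that bears most directly on it is the one from compound 1 to compound 3, where phenyl replaced sulfoamino on the same saturated ring carbon and gave a 35-fold higher number from compound 1 to compound 3 (1.55 log units; beyond the scatter), a large rise. Amino, like sulfoamino, carries a hydrogen-bond donor and acceptor, so the return from phenyl to a small polar group is expected to reverse most of that rise. The step from compound 1 to compound 2, at a 5.4-fold higher number from compound 1 to compound 2 (0.73 log units; beyond the scatter), shows that even a plain methyl on the ring sits well below compound 3. A large fall in this assay is therefore expected, a 22-fold lower number from compound 3 to compound 4 (1.34 log units; beyond the scatter), and compound 4 is estimated at 80 nM, within the range 20 nM to 400 nM.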

Compound 4, half-maximal effective concentration: 200 nM
Beside the measured number, compound 4's estimate is 2.5-fold (0.40 log units) below it, within the range that was stated.
By their numbers in this assay, from the lowest: compound 1; then compounds 4 and 2 (each within the scatter of the next); then compound 3.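

In this assay, amino in place of phenyl on this saturated ring carbon gives an 8.9-fold lower number from compound 3 to compound 4 (0.95 log units; beyond the scatter), so a single nitrogen recovers much of the distance to the sulfoamino compound without any sulfo group. The sulfo group still counts, as hydrogen in its place on the amine nitrogen gives a 4.0-fold higher number from compound 1 to compound 4 (0.60 log units; beyond the scatter), so the plain amine alone does not account for compound 1. Compound 4 cannot be separated from compound 2, with a 1.4-fold lower number from compound 2 to compound 4 (0.13 log units; within the scatter), so 3-aminopyrrolidin-1-yl and 2-methylpyrrolidin-1-yl on the shared core give numbers within the scatter of each other.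

No measurement here explains any of these steps. Going by these compounds, it remains open whether a methylamine, an acetamide or a carboxylic acid on the same ring carbon would stand nearer compound 1 or compound 4.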